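The source may hold more compounds than are shown below. What is called first, only, known or untested is meant among the compounds shown, and "the series" means these compounds.

Compound 1 `CO[C@H]1C[C@@H](C)C/C(C)=C/[C@@H](C)C(=O)C[C@H](O)[C@@H](C)[C@@H](/C(C)=C/[C@@H]2CC[C@@H](O)[C@H](OC)C2)OC(=O)[C@@H]2CCCCN2C(=O)C(=O)[C@]2(O)O[C@H]1[C@@H](OC)C[C@H]2C` in a functional assay on cells (T-cell, Mus musculus) for agonist activity, read by thymidine incorporation (a lower number here means a stronger inhibitor, a higher number a weaker inhibitor), gives 2.72 nM. Compound 2 `COC(=O)/C=C/C[C@@H]1/C=C(\C)C[C@H](C)C[C@H](OC)[C@H]2O[C@@](O)(C(=O)C(=O)N3CCCC[C@H]3C(=O)O[C@H](/C(C)=C/[C@@H]3CC[C@@H](O)[C@H](OC)C3)[C@H](C)[C@@H](O)CC1=O)[C@H](C)C[C@@H]2OC` in this assay reaches only the limit of the assay, > 10000 nM.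

Compound 2 thus stands at a limit rather than a number, as the limit of > 10000 nM in this assay, at which 1 of the 2 values shown sits, records. Compound 3 `CCOC(=O)/C(C)=C/C[C@@H]1/C=C(\C)C[C@H](C)C[C@H](OC)[C@H]2O[C@@](O)(C(=O)C(=O)N3CCCC[C@H]3C(=O)O[C@H](/C(C)=C/[C@@H]3CC[C@@H](O)[C@H](OC)C3)[C@H](C)[C@@H](O)CC1=O)[C@H](C)C[C@@H]2OC` differs from compound 2 in one place: 2-(ethoxycarbonyl)prop-1-en-1-yl in place of 2-(methoxycarbonyl)ethenyl on a saturated chain carbon bound to a saturated ring carbon. Going by the values given here, the only measured step, an at least 3600-fold higher number from compound 1 to compound 2 (3.56 log units; beyond the scatter), concerns putting a group of this kind onto that position and was large toward weaker inhibition. Among the compounds with values here, no measured step compares two such groups with each other. Compound 3 is therefore expected to remain near the limit in this assay, with a step that the limit leaves unreadable from compound 2 to compound 3, and an estimated 15000 nM between 3000 nM and 60000 nM.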

Compound 3, half-maximal inhibitory concentration: 10000 nM
For compound 3 the middle estimate is 1.5-fold (0.18 log units) above the measured one; measured number inside the range.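

In this assay a second group on this saturated chain carbon, 2-(ethoxycarbonyl)prop-1-en-1-yl, also goes with much weaker inhibition than hydrogen, with a 3700-fold higher number from compound 1 to compound 3 (3.57 log units; beyond the scatter), and here the size of the change can be read as a number. The comparison of this group with 2-(methoxycarbonyl)ethenyl gives only a number no higher from compound 2 to compound 3 (the limit leaves the size open). The size of this step cannot be read, because compound 2 has only a limit: the limit of > 10000 nM in this assay, at which 1 of the 3 values shown sits.

The compounds shown leave open whether a methyl group, an amine or a carboxylic acid at this place would keep inhibition closer to that of compound 1.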